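Adding a methoxy group beside the amino group

The source may hold more compounds than are shown below. What is called first, only, known or untested is meant among the compounds shown, and "the series" means these compounds.

Of the compounds shown here, three built on a shared core have been measured in an assay on isolated protein for inhibition of high affinity nerve growth factor receptor (Homo sapiens), read by 33P incorporation; a lower number here means a stronger inhibitor, a higher number a weaker inhibitor. Compound 3 `Nc1cccc(-c2cnc3[nH]cc(-c4ccncc4)c3c2)c1` gives 42.7 nM there, the second highest of the three numbers. Compound 1 `COc1ccc(N)cc1-c1cnc2[nH]cc(-c3ccncc3)c2c1`, which carries a methoxy group elsewhere on the same ring, gives 110 nM, and the step of a 2.6-fold lower number from compound 1 to compound 3 (0.41 log units; beyond the scatter) shows that removing that methoxy lowered the number. Compound 2 `Cc1ccc(S(=O)(=O)Nc2cc(N)cc(-c3cnc4[nH]cc(-c5ccncc5)c4c3)c2)cc1`, with a large sulfonylamino substituent, gives 4.62 nM, and the step of a 9.2-fold higher number from compound 2 to compound 3 (0.97 log units; beyond the scatter) shows that stripping that group raised the number.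

Compound 4 `COc1ccc(-c2cnc3[nH]cc(-c4ccncc4)c3c2)cc1N` differs from compound 3 by a single change: methoxy in place of hydrogen on an aromatic carbon. For the measured compounds named here, only the step from compound 1 to compound 3 bears directly on this, since it too concerns a methoxy group on this ring, and it was modest in size. The new methoxy, however, sits at a different position, ortho to the amino group and para to a large group, so the earlier step gives only a rough guide. A modest shift is therefore expected, most likely toward a higher number, in the direction seen when the methoxy of compound 1 was present. For compound 4 the expected step is a 1.6-fold higher number from compound 3 to compound 4 (0.21 log units; within the scatter), so compound 4 is estimated at 70 nM, within a range from 25 nM to 200 nM.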

Compound 4, half-maximal inhibitory concentration: 33.2 nM
The estimate for compound 4 lay 2.1-fold (0.32 log units) above the measured number; low and high end bracket the measured number.
By their numbers in this assay, from the lowest: compound 2; then compounds 4 and 3 (each within the scatter of the next); then compound 1.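

Placing a methoxy group on this carbon, ortho to the amino group and para to a large group, gives a 1.3-fold lower number from compound 3 to compound 4 (0.11 log units; within the scatter) in this assay, so the two compounds cannot be told apart in this assay and the added group leaves no readable mark. For the compounds shown here, the earlier compounds could not show this, since their only methoxy step, a 2.6-fold lower number from compound 1 to compound 3 (0.41 log units; beyond the scatter), concerns a methoxy elsewhere on the same ring and lies beyond the scatter. Set side by side, the two steps show that the same small group on the same ring can matter in one place and not in another, so the effect of a methoxy on this ring cannot be carried from one place to the next, and nothing shown here accounts for the difference.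

The compounds shown do not tell whether this place would stay as undemanding with a hydroxyl, an ethoxy group or a longer chain in place of the methoxy. They also leave open whether a methoxy here would change the number when the ((4-methylphenyl)sulfonyl)amino group of compound 2 is also on the ring.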